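The compounds below may be only part of what the source reports. "The series", "measured", "known", "first", "only" and "open" are said of these compounds alone.

Measured in a functional assay on MCF7 cells (Homo sapiens); on this read-out higher numbers stand for weaker inhibition of growth and lower numbers for stronger inhibition of growth:
Compound 1 `O=S(=O)(/C=C/c1ccc(F)cc1F)Cc1ccc(Nc2ncnc3ccccc23)cc1`: > 100000 nM
Compound 2 `O=S(=O)(/C=C/c1ccc(F)cc1Cl)Cc1ccc(Nc2ncnc3cc(Cl)ccc23)cc1`: 15000 nM

Compound 1 gives > 100000 nM, which is a limit of this assay, not a number. Among the measured compounds shown here, compound 2, at 15000 nM, therefore holds the only numerical value so far, and no measured step is available for comparison. Compound 3 `O=S(=O)(/C=C/c1ccc(F)cc1F)Cc1ccc(Nc2ncnc3cc(Cl)ccc23)cc1` differs from compound 2 by fluoro in place of chloro on an aromatic carbon, with fluoro in place of chloro on an aromatic carbon. The estimated change a 1.3-fold higher number from compound 2 to compound 3 (0.12 log units; within the scatter) is expected to stay within the scatter, leaning slightly toward weaker inhibition of growth. Compound 3 is expected at 20000 nM, with an estimated range of 7000 nM to 60000 nM.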

Compound 3, concentration for 50% growth inhibition: > 100000 nM
Compound 3 was reported as a limit; the forecaster's own chance of this, stated with the estimate: 15%; middle value at least 5.0-fold (0.69 log units) from the limit.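

Among the compounds shown here, with chloro on the shared core in place, fluoro in place of chloro on the aromatic carbon ortho to a large group gives an at least 6.6-fold higher number from compound 2 to compound 3 (0.82 log units; beyond the scatter) in this assay, the first readable step here, and it shows that this position is not indifferent to the change. Compound 3 gives > 100000 nM, which is a limit of the assay, and the step from compound 1 cannot be read. The step's full size stays hidden: the limit of > 100000 nM in this assay, at which 2 of the 3 values shown sit.

From the compounds shown here alone, whether bromo or methyl at this position would give a lower or higher number than chloro remains open.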